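A few compounds are considered here, and "the series" means these few. Any claim that something is new, unique, unknown or untested is made for them only; others in the source may bear on it.

Compound 3 `O=C(CCCCCCCc1ccccc1)CC(=O)N[C@H]1CCOC1=O` and compound 1 `O=C(CCCCCc1ccccc1)CC(=O)N[C@H]1CCOC1=O` share a core that carries a second carbonyl in the chain, while compound 2 `O=C(CCCCCCCCCCc1ccccc1)N[C@H]1CCOC1=O` and the yet unmeasured compound 4 `O=C(CCCCCCCCc1ccccc1)N[C@H]1CCOC1=O` share a core in which the chain runs uninterrupted from the amide; the difference between the two cores is not broken down here. In a functional assay on NCI-H630 cells (Homo sapiens) for cytotoxicity, read by sulforhodamine B assay, with a stated time of 5 days (a lower number here means a stronger inhibitor, a higher number a weaker inhibitor), compound 3 gives 10000 nM, and compound 1 gives 24000 nM, so the step of a 2.4-fold higher number from compound 3 to compound 1 (0.38 log units; beyond the scatter) follows the change (phenyl in place of phenethyl on a saturated chain carbon, five bonds along the chain from a carbonyl carbon). In this assay compound 2 gives 66000 nM, the highest number of the three measured compounds. Compound 4 is reached from compound 2 by the change (phenyl in place of phenethyl on a saturated chain carbon, eight bonds along the chain from a carbonyl carbon). Among the measured compounds shown here, this is the same kind of change as the one from compound 3 to compound 1, but not the same: there the change sits five bonds along the chain from a carbonyl carbon, here eight bonds along the chain from a carbonyl carbon. For the measured compounds named here, for compound 4 a step of about the same size and direction is expected, a 2.1-fold higher number from compound 2 to compound 4 (0.33 log units; beyond the scatter), because the only measured example of this kind of change, a 2.4-fold higher number from compound 3 to compound 1 (0.38 log units; beyond the scatter), made the number higher, and because compound 2 already stands at 66000 nM, so the result may approach the upper reach of this assay. Compound 4 is therefore estimated at 140000 nM in this assay, expected to lie between 50000 nM and 350000 nM.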

Compound 4, half-maximal inhibitory concentration: > 100000 nM
Compound 4: a limit, no number; the forecaster's own chance of this, stated with the estimate: 30%; the middle value is on the limit's open side.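

In this assay compound 4 gives > 100000 nM, which is a limit of the assay and not a number: the limit of > 100000 nM in this assay, at which 1 of the 4 values shown sits. The change of phenyl in place of phenethyl, on a saturated chain carbon, eight bonds along the chain from a carbonyl carbon, gives an at least 1.5-fold higher number from compound 2 to compound 4 (0.18 log units; that floor lies within the scatter), which points the same way as the step on the core of compound 3, although the floor of this step does not by itself reach beyond the scatter. Carried from one core to the other, the change therefore makes the number higher on both as far as can be read, but this does not show that it has the same size on both, since its full size on the core of compound 2 remains unknown: the same change on two cores in this assay, a 2.4-fold higher number (0.38 log units; beyond the scatter) from compound 3 to compound 1 and an at least 1.5-fold higher number (0.18 log units; that floor lies within the scatter) from compound 2 to compound 4; the limit leaves it open whether they differ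

The compounds shown leave open how the number would move with a chain longer than that of compound 2, or with a carboxylic acid or an amine in place of the phenyl at the chain end. No pair shown isolates the second carbonyl in the chain, so its part in these numbers also stays open.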